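From Fluoro to Nitro: an Unmeasured Analogue

This account rests on a few compounds, and the source may have more. Where it says the series, first, only, none or still open, it means among the compounds named here.

Compound 1 `O=C1C=CC[C@@H](/C=C/c2ccc(F)cc2)O1` was tested in a functional assay on A549 cells (Homo sapiens) for antiproliferative activity, read by luminescence and CellTiter-Glo, with a stated time of 48 h; a lower number here means a stronger inhibitor, a higher number a weaker inhibitor. In this assay compound 1 reaches only a limit, > 100000 nM, so no number is known for it; it stands at the limit of > 100000 nM in this assay, at which 1 of the 2 values shown sits. Compound 2 `O=C1C=CC[C@H]([C@@H]2C[C@H]2c2ccccc2)O1`, which carries a different arm on the shared core, gives 62800 nM in this assay. Going by the values given here, no step between two measured compounds is available, so these two values can only be set side by side, and both point to weak inhibition.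

Compound 3 `O=C1C=CC[C@@H](/C=C/c2ccc([N+](=O)[O-])cc2)O1` has not yet been measured. It differs from compound 1 by nitro in place of fluoro on an aromatic carbon. Because compound 1 is known only as a limit, the step cannot be anchored; a change of this kind is expected to stay within the scatter, or at most move slightly toward stronger inhibition. Compound 3 is therefore expected to give about 80000 nM in this assay, with a likely range from 20000 nM to 200000 nM, an estimated step of an at least 1.2-fold lower number from compound 1 to compound 3 (0.09 log units; that floor lies within the scatter).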

Compound 3, half-maximal inhibitory concentration: > 100000 nM
Compound 3: no number, only a limit; the forecaster's own chance of this, stated with the estimate: 45%; middle value at least 1.2-fold (0.09 log units) away from the limit.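

Compound 1 and compound 3 each reach only a limit, so no step can be read for nitro in place of fluoro on the aromatic carbon. Going by these compounds, what remains open is how strongly either compound inhibits and whether this exchange changes that strength at all.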